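Oxygen to sulfur in the sulfonamide ring of compound 2

The source may report more compounds than this note shows. Statements on the series, on what has been measured and on what is new or still open speak of the compounds shown alone.

Of the compounds shown here, three of a shared core have been measured in an assay for binding affinity to adenosine receptor A1 (Bos taurus); a lower number here means a stronger inhibitor, a higher number a weaker inhibitor. Compound 1 `COc1ccc(-c2nc3c(=O)n(C)c(=O)n(C)c3[nH]2)cc1OC` gives 22.5 nM, compound 2 `CCn1c(=O)c2nc(-c3ccc(S(=O)(=O)N4CCOCC4)cc3)[nH]c2n(CC)c1=O` gives 13 nM, and compound 3 `CCCn1c(=O)c2nc(-c3ccccc3N)[nH]c2n(CCC)c1=O` gives 0.75 nM. Compound 2 thus holds the second highest of the three numbers: its value and that of compound 1 lie within the usual scatter of each other, while compound 3 stands beyond the scatter with a clearly lower number.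

Compound 4 `CCn1c(=O)c2nc(-c3ccc(S(=O)(=O)N4CCSCC4)cc3)[nH]c2n(CC)c1=O` has not yet been measured. It differs from compound 2 in one place: thiomorpholin-4-yl in place of morpholin-4-yl on a sulfonyl sulfur. The ring that leaves and the ring that enters have the same number of heavy atoms, the same ring size and the same count of donors and acceptors, with only oxygen exchanged for sulfur. No measured pair shows this exchange, so there is no shown step to lean on. Compound 4 is expected to give a number close to that of compound 2, with a step of a 1.1-fold lower number from compound 2 to compound 4 (0.03 log units; within the scatter) that is not expected to exceed the scatter in either direction. The estimate for compound 4 in this assay is 12 nM, expected to fall between 5 nM and 30 nM.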

Compound 4, half-maximal inhibitory concentration: 36.6 nM
Estimate against measurement, compound 4: 3.1-fold (0.48 log units) below, outside the stated range (above it).
By their numbers in this assay, from the lowest: compound 3; then compounds 2, 1 and 4 (each within the scatter of the next, the first and the last beyond it).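

In this assay, thiomorpholin-4-yl in place of morpholin-4-yl on a sulfonyl sulfur gives a 2.8-fold higher number from compound 2 to compound 4 (0.45 log units; beyond the scatter) and so yields a modest step, yet one beyond the scatter. Among the compounds shown here, the earlier compounds offered no pair differing in one place, so this is the first sign that the number at this position responds to the ring: the two rings match in size and in their counts of heavy atoms, donors and acceptors, with only oxygen exchanged for sulfur. The data shown offer nothing that explains this step.

The compounds shown leave open how a piperidin-1-yl ring, a piperazin-1-yl ring or a dimethylamino group on the same sulfonyl sulfur would read. They also leave open whether the same exchange gives a similar step with propyl chains in place of the ethyl chains on the shared core.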